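The source may hold more compounds than are shown below. What is called first, only, known or untested is meant among the compounds shown, and "the series" means these compounds.

Compound 3 `CCCCCCCCCOC(=O)CCC(=O)N1CCN(CCCOc2cc3c(Nc4ccc(F)c(Cl)c4)ncnc3cc2OC)CC1` stands lowest of the three measured numbers in a functional assay on A549 cells (Homo sapiens) for cytotoxicity, read by MTT assay, with a stated time of 24 h, tested at 60 uM; a higher number here means a weaker effect of the compound at the concentration tested, a lower number a stronger effect: compound 3 gives 10.3%, while compound 2 `CCCCCOC(=O)CCC(=O)N1CCN(CCCOc2cc3c(Nc4ccc(F)c(Cl)c4)ncnc3cc2OC)CC1` gives 30% and compound 1 `CCCOC(=O)CCC(=O)N1CCN(CCCOc2cc3c(Nc4ccc(F)c(Cl)c4)ncnc3cc2OC)CC1` gives 70.4%. Compound 4 `CCCCCCCCCCCCCCOC(=O)CCC(=O)N1CCN(CCCOc2cc3c(Nc4ccc(F)c(Cl)c4)ncnc3cc2OC)CC1` differs from compound 3 by pentyl in place of hydrogen on a saturated chain carbon, nine bonds along the chain from an oxygen next to a carbonyl group. The earlier chain extensions bear on this change: a number 40.4 percentage points lower from compound 1 to compound 2 (beyond the scatter), a number 60.1 percentage points lower from compound 1 to compound 3 (beyond the scatter), and a number 19.7 percentage points lower from compound 2 to compound 3 (beyond the scatter), so each added length lowered the number, and the later, longer extension brought the smaller change. A further but smaller drop is therefore expected in this assay , although the number of compound 3 leaves little room beneath it. For compound 4 the estimate is 6%, between 0% and 18%. The expected step is a number 4.3 percentage points lower from compound 3 to compound 4 (within the scatter).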

Compound 4, a percentage reported as activity, at one concentration (the size of the read-out at that concentration, not a potency): 84.9%
For compound 4 the middle estimate is 78.9 percentage points below the measured one, outside the stated range (above it).
By their numbers in this assay, from the lowest: compound 3; then compound 2; then compound 1; then compound 4.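

Lengthening the chain does not keep lowering the number in this assay: the pentyl extension reverses the earlier trend, with a number 74.6 percentage points higher from compound 3 to compound 4 (beyond the scatter). The longest chain also stands weaker than both shorter ones, with a number 54.9 percentage points higher from compound 2 to compound 4 (beyond the scatter) and a number 14.5 percentage points higher from compound 1 to compound 4 (beyond the scatter), so the effect of chain length at this position is not one-directional, and compound 3 has the lowest number of the four. Nothing measured here accounts for this reversal. Going by these compounds, it remains open how the number changes for a chain of intermediate length, such as compound 3 with ethyl in place of that hydrogen. A long chain ending in an amine or a carboxylic acid is also an open case.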